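Sulfonyl aryl change on the quinoline sulfone series

The compounds below may be only part of what the source reports. "The series", "measured", "known", "first", "only" and "open" are said of these compounds alone.

Measured compounds in an assay on isolated protein for displacement of a labelled ligand from metabotropic glutamate receptor 5 (Homo sapiens), with a stated time of 60 min, tested at 1 uM; on this read-out higher numbers stand for more inhibition at the one concentration tested (going by the name of the read-out) and lower numbers for less inhibition:
compound 1 `Cc1ccc(S(=O)(=O)c2cnc3ccc(F)cc3c2N2CCC(C)CC2)cc1` gives 91%;
compound 2 `Cc1ccc(S(=O)(=O)c2cnc3ccc(Cl)cc3c2N2CCC(C)CC2)cc1` gives 95%;
compound 3 `CC1CCN(c2c(S(=O)(=O)c3ccccc3)cnc3ccc(F)cc23)CC1` gives 40%.

Compound 2 holds the highest number of the three in this assay; the step of a number 4 percentage points higher from compound 1 to compound 2 (within the scatter) is within the scatter, so compound 1 and compound 2 are not distinguished, while compound 3 lies well apart.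

Compound 4 `CC1CCN(c2c(S(=O)(=O)c3ccc(Cl)c(Cl)c3)cnc3ccc(Cl)cc23)CC1` differs from compound 2 by 3,4-dichlorophenyl in place of 4-methylphenyl on a sulfonyl sulfur. The step that bears on this place is a number 51 percentage points lower from compound 1 to compound 3 (beyond the scatter), where the aryl on the sulfonyl sulfur was altered; that step was large. The step of a number 4 percentage points higher from compound 1 to compound 2 (within the scatter), a halogen change on the core, was small. A change on the sulfonyl aryl may therefore move the number markedly, but the direction is not settled by the pairs measured. A moderate loss is expected, a number 20 percentage points lower from compound 2 to compound 4 (beyond the scatter), and compound 4 is estimated at 75%, between 45% and 95%.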

Compound 4, a percentage reported as inhibition, at one concentration (the size of the read-out at that concentration, not a potency): 86%
Beside the measured number, compound 4's estimate is 11 percentage points below it, within the range that was stated.
By their numbers in this assay, from the lowest: compound 3; then compounds 4, 1 and 2 (each within the scatter of the next).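

In this assay, 3,4-dichlorophenyl in place of 4-methylphenyl on a sulfonyl sulfur gives a number 9 percentage points lower from compound 2 to compound 4 (within the scatter), so these two compounds are not distinguished. The earlier step at this place, a number 51 percentage points lower from compound 1 to compound 3 (beyond the scatter), showed only a large loss; this pair shows that the methyl is not needed on every aryl that holds the number in this range. No measurement bears on why this is so.

As far as these compounds go, it remains open whether a single chlorine on the aryl would serve as well. Also open, from the compounds shown here alone, is how a methoxy group, an amine or a carboxylic acid on that aryl would read.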